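The compounds below may be only part of what the source reports. "The series", "measured", "known", "first", "only" and "open" are said of these compounds alone.

Two close analogues of one shared core open this account. Compound 1 `CCOC(=O)c1c(C)[nH]c(=O)c(C#N)c1-c1ccc([N+](=O)[O-])cc1` carries a nitrophenyl group on the core, and compound 2 `CCOC(=O)c1c(C)[nH]c(=O)c(C#N)c1-c1cccs1` carries a thiophen-2-yl group in the same position. Both were examined in a functional assay on aorta (Rattus norvegicus) for inhibition; on this read-out lower numbers stand for smaller maximal responses and higher numbers for larger maximal responses. In this assay compound 1 reaches 98%, and compound 2 reaches 100%. The two readings differ by an amount that lies within the usual scatter of such measurements, so compound 2 stands level with compound 1 rather than apart from it: on the numbers at hand, both compounds reach essentially the full response of the reference.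

The next step leads to compound 3 `CCOC(=O)c1c(C)[nH]c(=O)c(C#N)c1-c1ccncc1`. Compared with compound 2, the change is pyridin-4-yl in place of thiophen-2-yl on an aromatic carbon. For the measured compounds named here, no measured pair in this set shows what this kind of exchange does to the maximal response, so the expectation rests only on the two values already seen. Since compound 2 gives 100%, essentially the full response of the reference, compound 3 is expected to show no step beyond the scatter, an expected change of a number 5 percentage points lower from compound 2 to compound 3 (within the scatter). For compound 3 an estimated 95% in this assay, with a range from 78% to 105%, is therefore expected.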

Compound 3, largest response reached (reported as efficacy), in percent of the reference or control that the assay uses: 85.5%
For compound 3 the middle estimate is 9.5 percentage points above the measured one; measured number inside the range.
By their numbers in this assay, from the lowest: compound 3; then compounds 1 and 2 (each within the scatter of the next).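

Putting pyridin-4-yl in place of thiophen-2-yl on the aromatic carbon opposite the ring nitrogen of the shared core gives, in this assay, a number 14.5 percentage points lower from compound 2 to compound 3 (beyond the scatter), a modest step but the only one in this set that is printed as beyond the scatter. Compound 1 and compound 2 had stood level despite carrying different aromatic groups here, so they gave no sign that the group at this position could change the maximal response, whereas this single exchange shows that it can, although compound 3 still reaches 85.5%. Nothing available here accounts for the step, which therefore stands as an observation without an explanation.

The compounds shown leave open whether the place of the nitrogen within the six-membered ring matters, as pyridin-3-yl, pyridin-2-yl and plain phenyl do not appear among them at this position. They also leave open what an amine or a carboxylic acid on that aromatic ring would do to the maximal response, and whether a longer chain in place of the ethoxycarbonyl group would change the picture.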